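Tert-butyl in place of methyl on the aromatic carbon

This account rests on a few compounds, and the source may have more. Where it says the series, first, only, none or still open, it means among the compounds named here.

Compound 2 `Cc1ccc(OCCCCCCN2CCN(c3cccnc3)C2=O)cc1` carries a methyl group on an aromatic carbon. In a functional assay on cells (Homo sapiens) for cytotoxicity (on this read-out lower numbers stand for higher toxicity in this test and higher numbers for lower toxicity in this test), compound 2 gives > 25000 nM, which is a limit of the assay and not a number. Compound 1 `O=C1N(CCCCCCOc2ccc(Cl)cc2)CCN1c1cccnc1` carries chloro at that aromatic carbon instead. In this assay compound 1 gives > 25000 nM, likewise a limit. The step from compound 1 to compound 2 is a step that the two limits leave unreadable from compound 1 to compound 2; both values sit at the limit of > 25000 nM in this assay, at which 2 of the 2 values shown sit, so no readable step bears on the next change. Compound 3 `CC(C)(C)c1ccc(OCCCCCCN2CCN(c3cccnc3)C2=O)cc1` carries tert-butyl in place of methyl on an aromatic carbon. Compound 3 is expected at 25000 nM, with a range from 8000 nM to 60000 nM. The expected step from compound 2 to compound 3, a number no higher from compound 2 to compound 3 (the limit leaves the size open), is none beyond the scatter.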

Compound 3, half-maximal cytotoxic concentration: > 25000 nM
Compound 3: only a limit was reported; the forecaster's own chance of this, stated with the estimate: 65%; the middle value lies on the limit itself.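

No new step can be read between compound 1, compound 2 and compound 3 in this assay, where each value is a limit and not a number: the limit of > 25000 nM in this assay, at which 3 of the 3 values shown sit. The compounds shown leave open how chloro, methyl and tert-butyl on this aromatic carbon compare.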